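The source may report more compounds than this note shows. Statements on the series, on what has been measured and on what is new or still open speak of the compounds shown alone.

Working notes on the series. In a functional assay on DU-145 cells (Homo sapiens) for cytotoxicity, read by ELISA, with a stated time of 4 days (on this read-out higher numbers stand for weaker inhibition and lower numbers for stronger inhibition), compound 1 (`Cc1ccsc1-c1cc(-c2ccco2)cc(-c2ccc(Cl)cc2)n1`) gives 26700 nM, compound 2 (`Cc1ccsc1-c1cc(-c2ccoc2)cc(-c2ccc(Cl)cc2)n1`) gives 20100 nM and compound 3 (`Cc1cccc(-c2cc(-c3ccoc3)cc(-c3ccc(Cl)s3)n2)c1`) gives 20300 nM. Compound 3 lies within the scatter of both other compounds, so the three stand level.

The next step leads to compound 4 (`Clc1ccc(-c2cc(-c3ccoc3)cc(-c3cccnc3)n2)s1`), with pyridin-3-yl in place of 3-methylphenyl on an aromatic carbon.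

For the measured compounds named here, only one measured step is available, a 1.3-fold lower number from compound 1 to compound 2 (0.12 log units; within the scatter). It concerns furan-3-yl in place of furan-2-yl, a different exchange in a different place, and it stays within the scatter. Going by the values given here, no measured step covers the loss of 3-methylphenyl or the entry of pyridin-3-yl, so the data favour no direction. In this assay, no step beyond the scatter is expected, though this rests on thin evidence.

The expected change is a 1.1-fold lower number from compound 3 to compound 4 (0.05 log units; within the scatter). Compound 4 is estimated at 18000 nM, with an expected range of 6000 nM to 45000 nM.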

Compound 4, half-maximal inhibitory concentration: 18500 nM
Compound 4: the middle estimate sits 1.0-fold (0.01 log units) below what was measured, and the stated range covers the measured number.
By their numbers in this assay, from the lowest: compounds 4, 2, 3 and 1 (each within the scatter of the next).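

In this assay, for the compounds shown here, pyridin-3-yl in place of 3-methylphenyl, on the aromatic carbon next to the ring nitrogen, gives a 1.1-fold lower number from compound 3 to compound 4 (0.04 log units; within the scatter), the first measured exchange at this position. A ring of carbon only and a ring with a nitrogen and a hydrogen-bond acceptor therefore stand level here, with the 5-chlorothiophen-2-yl and furan-3-yl groups held constant. No supporting measurement is available to explain this outcome.

The compounds shown leave open whether the level holds for a group of another kind at this position, such as an amine, a carboxylic acid or a longer chain in place of the aromatic ring. They also leave open whether pyridin-3-yl behaves the same way when furan-2-yl replaces furan-3-yl.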